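A few compounds are considered here, and "the series" means these few. Any claim that something is new, unique, unknown or untested is made for them only; others in the source may bear on it.

Of the compounds shown here, three have numbers so far in a physicochemical assay for lipophilicity; on this read-out lower numbers stand for lower lipophilicity and higher numbers for higher lipophilicity. Compound 1 `CCCCCCNC(=O)c1ccc(S(N)(=O)=O)cc1` gives 2.05, compound 2 `CCOC(=O)c1cccc(S(N)(=O)=O)c1` gives 1.11, and compound 3 `CCCOC(=O)c1cccc(S(N)(=O)=O)c1` gives 1.72. That makes compound 3 the second highest of the three, with a value lower than that of compound 1 and higher than that of compound 2, both gaps lying beyond the usual scatter of repeat measurements.

Compound 4 `CCCCOC(=O)c1cccc(S(N)(=O)=O)c1` has not yet been measured. It differs from compound 3 in one place: methyl in place of hydrogen on a saturated chain carbon, three bonds along the chain from an oxygen next to a carbonyl group. In words, this is methyl in place of hydrogen on a saturated chain carbon, three bonds along the chain from an oxygen next to a carbonyl group, the same difference that reads propyl to butyl.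

Going by the values given here, one measured step bears on this change: methyl in place of hydrogen on a saturated chain carbon, two bonds along the chain from an oxygen next to a carbonyl group. With that single guide, a number 0.61 log units higher from compound 2 to compound 3 (beyond the scatter), a rise of similar size, beyond the scatter, is expected in this assay. The estimated step is a number 0.55 log units higher from compound 3 to compound 4 (beyond the scatter). The estimate for compound 4 is 2.27, with an expected range from 2 to 2.55.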

Compound 4, partition coefficient: 2.24
The estimate for compound 4 lay 0.03 log units above the measured number, and the stated range covers the measured number.
By their numbers in this assay, from the lowest: compound 2; then compound 3; then compounds 1 and 4 (each within the scatter of the next).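

In this assay, going by these compounds alone, methyl in place of hydrogen on a saturated chain carbon, three bonds along the chain from an oxygen next to a carbonyl group, gives a number 0.52 log units higher from compound 3 to compound 4 (beyond the scatter), so the propyl to butyl change moves the number beyond the scatter, as the single earlier step of this kind did one bond closer to that oxygen. Read as one change, the two steps together give a number 1.13 log units higher from compound 2 to compound 4 (beyond the scatter), a large step built from two modest ones. Across compound 2, compound 3 and compound 4, then, each added carbon raises the number, and none of these three goes against that pattern, though it rests on only two single steps.

As far as these compounds go, whether the rise carries on with a longer chain such as pentyl or hexyl, and what a branched chain, an amine or a carboxylic acid would do at this place, stays open. Nothing available here offers an explanation for these rises.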